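Dropping One Chloro from Compound 2: What to Expect

This account rests on a few compounds, and the source may have more. Where it says the series, first, only, none or still open, it means among the compounds named here.

Measured compounds:
compound 1, `CN1CCN(CCCOc2cccc3nc(Nc4ccc(F)c(F)c4)ccc23)CC1`: 12200 nM
compound 2, `CN1CCN(CCCOc2cccc3nc(Nc4cc(Cl)cc(Cl)c4)ccc23)CC1`: 6100 nM

In a functional assay on cells (Panel colon (Carcinoma cell lines), Homo sapiens) for inhibition, read by sulforhodamine B assay, with a stated time of 48 h (on this read-out lower numbers stand for higher toxicity in this test and higher numbers for lower toxicity in this test), compound 1 gives 12200 nM, and compound 2 gives 6100 nM. Among the two numbers compound 2 holds the lowest, but the step of a 2.0-fold lower number from compound 1 to compound 2 (0.30 log units; within the scatter) falls within the scatter, so the two compounds cannot be told apart on this evidence.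

Compound 3, `CN1CCN(CCCOc2cccc3nc(Nc4cccc(Cl)c4)ccc23)CC1`, differs from compound 2 by hydrogen in place of chloro on an aromatic carbon. For the measured compounds named here, the only measured step, a 2.0-fold lower number from compound 1 to compound 2 (0.30 log units; within the scatter), swaps the whole halogen pattern of the phenyl ring in one move and stays within the scatter; no measured step removes a single chloro group while leaving the rest untouched. The basis for a forecast is therefore thin. Going by the values given here, since the one known change to this ring, a 2.0-fold lower number from compound 1 to compound 2 (0.30 log units; within the scatter), produced nothing beyond the scatter, the expected step of a 1.5-fold higher number from compound 2 to compound 3 (0.17 log units; within the scatter) is likewise expected to be modest, if anything towards a somewhat higher number. Compound 3 is accordingly estimated at 9000 nM in this assay, with a range from 3500 nM to 25000 nM.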

Compound 3, concentration lethal to 50% of the cells: 5870 nM
Compound 3: middle estimate off by 1.5-fold (0.19 log units), on the high side; measured number inside the range.
By their numbers in this assay, from the lowest: compounds 3, 2 and 1 (each within the scatter of the next, the first and the last beyond it).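

In this assay, taking one chloro group off the 3,5-dichlorophenyl ring leaves no readable difference (a 1.0-fold lower number from compound 2 to compound 3 (0.02 log units; within the scatter)), so on this aromatic carbon, meta to a chloro group, hydrogen and chloro cannot be told apart. For the compounds shown here, a single chloro group is therefore enough to match the 3,5-dichlorophenyl result, and the 3-chlorophenyl ring also gives the first step on this ring that passes the scatter (a 2.1-fold lower number from compound 1 to compound 3 (0.32 log units; beyond the scatter)), although that step is modest and the earlier step from the 3,4-difluorophenyl ring stayed within it. No available evidence explains either result.

Going by these compounds, what a plain phenyl ring, or a methoxy or trifluoromethyl group in place of the remaining chloro, would give in this assay stays open, and so does whether that chloro group contributes at all. Also open, on these data alone, is whether a longer chain between the oxygen and the amine, or a different amine at its end, would shift the number further than any change to this ring has.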